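Amide in place of ester on the shared core

This account rests on a few compounds, and the source may have more. Where it says the series, first, only, none or still open, it means among the compounds named here.

The series shares the core of compound 1, `COC(=O)c1nc(Br)c2cccnc2c1N[C@H]1CC[C@H](N)CC1`. For compound 1, a functional assay on SK-BR-3 cells (Homo sapiens) for cytotoxicity, read by MTT assay, with a stated time of 72 h (a higher number here means a weaker inhibitor, a lower number a stronger inhibitor), records "not determined" (no result reported), so no number is known for it, and the only further mark nearby is the limit of > 10000 nM in this assay, at which 1 of the 3 values shown sits. Compound 2, `NCCCNc1c(C(=O)NCc2ccc(F)cc2)ncc2cccnc12`, carries a propylamino chain and a fluorobenzyl carboxamide and lacks the bromine; in this assay compound 2 gives > 10000 nM, which is a limit of the assay and not a number. Compound 3, `O=C(NCc1ccc(F)cc1)c1nc(Br)c2cccnc2c1N1CCNCC1`, keeps the bromine with a piperazinyl group and the same fluorobenzyl carboxamide; in this assay compound 3 gives 6000 nM. No pair among these differs in a single place, so no step size is fixed.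

Compound 4, `N[C@H]1CC[C@H](Nc2c(C(=O)NC3CCCCC3)nc(Br)c3cccnc23)CC1`, is reached from compound 1 by one change: cyclohexylamino in place of methoxy on a carbonyl carbon. Nothing measured speaks to this change directly, and with compound 1 unmeasured no direction can be drawn from it; the bromine-bearing compound 3 is the nearest anchor. The expectation for compound 4 in this assay is 5000 nM, within 1500 nM to 20000 nM.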

Compound 4, half-maximal inhibitory concentration: 4200 nM
For compound 4 the middle estimate is 1.2-fold (0.08 log units) above the measured one, and the stated range covers the measured number.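

For the compounds shown here, with compound 1 recorded as "not determined" (no result reported) in this assay, no step from it to compound 4 can be read. The compounds shown leave open what methoxycarbonyl to cyclohexylcarbamoyl alone does on the shared core, and the only further mark remains: the limit of > 10000 nM in this assay, at which 1 of the 4 values shown sits.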